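Chloro to fluoro swap carried onto a second core

A few compounds are considered here, and "the series" means these few. Any claim that something is new, unique, unknown or untested is made for them only; others in the source may bear on it.

In a functional assay on SK-OV-3 cells (Homo sapiens) for antiproliferative activity, read by MTT assay (on this read-out higher numbers stand for weaker inhibition and lower numbers for stronger inhibition), compound 1 `Cc1ccc(C(=O)C(=C2NCCN2)c2c(Cl)c(F)c(C#N)c(F)c2C#N)cc1` gives 6.7 ug/mL. Compound 2 `Cc1ccc(C(=O)C(=C2NCCN2)c2c(F)c(F)c(C#N)c(F)c2C#N)cc1` differs from compound 1 by fluoro in place of chloro on an aromatic carbon; in this assay compound 2 gives 2 ug/mL, a step of a 3.4-fold lower number from compound 1 to compound 2 (0.53 log units; beyond the scatter). Compound 3 `N#Cc1c(F)c(Cl)c(C(C(=O)c2ccc(F)cc2)=C2NCCCN2)c(C#N)c1F` carries a second core; how it differs from the core of compound 1 is not broken down here. In this assay compound 3 gives 8.2 ug/mL, close to the number of compound 1. Compound 4 `N#Cc1c(F)c(F)c(C(C(=O)c2ccc(F)cc2)=C2NCCCN2)c(C#N)c1F` differs from compound 3 by fluoro in place of chloro on an aromatic carbon, the same change at the same place as that between compound 1 and compound 2. This change has been seen only once, so the expectation rests on that one step alone. Compound 4 is expected to show a step of a 3.4-fold lower number from compound 3 to compound 4 (0.53 log units; beyond the scatter) because the same change gave a 3.4-fold lower number from compound 1 to compound 2 (0.53 log units; beyond the scatter). Compound 4 is estimated at 2.4 ug/mL, within an expected range of 1.2 ug/mL to 5 ug/mL.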

Compound 4, half-maximal inhibitory concentration: 0.5 ug/mL
Compound 4: the middle estimate sits 4.8-fold (0.68 log units) above what was measured; the measured number lies below the stated range.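

In this assay the fluoro in place of chloro on the second core gives a 16-fold lower number from compound 3 to compound 4 (1.21 log units; beyond the scatter), so the change keeps its direction on both cores but not its size: the same change on two cores in this assay, a 3.4-fold lower number (0.53 log units; beyond the scatter) from compound 1 to compound 2 and a 16-fold lower number (1.21 log units; beyond the scatter) from compound 3 to compound 4, 4.9-fold (0.69 log units) apart, beyond the scatter of two such steps

Among these compounds, with only two cores, the earlier step could predict the direction of the change but not its size. The two cores differ in more than one place, and these four compounds do not show which difference goes with the larger step.

As far as these compounds go, it remains open how a bromo, methoxy or amino group would read on this same aromatic carbon. Also open, from the compounds shown here alone, is how large the step would be on a further core, for instance one carrying an amine in place of a cyano group.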